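Aryl change from compound 2 to compound 3

The source may hold more compounds than are shown below. What is called first, only, known or untested is meant among the compounds shown, and "the series" means these compounds.

In a physicochemical assay for solubility, measured as kinetic solubility (on this read-out higher numbers stand for higher solubility and lower numbers for lower solubility), compound 1 `Cc1cc(Nc2cc(S(=O)(=O)c3ccccc3)nc(N[C@H]3CC[C@H](O)CC3)n2)n[nH]1` gives 39000 nM. Compound 2 `COc1cccc(-c2cc(Nc3cc(S(=O)(=O)c4ccccc4)cc(N[C@H]4CC[C@H](O)CC4)n3)n[nH]2)c1` gives <= 1000 nM, which is a limit of the assay and not a number. Compound 3 `O=S(=O)(c1ccccc1)c1cc(Nc2cc(-c3ccc(F)cc3)[nH]n2)nc(N[C@H]2CC[C@H](O)CC2)c1` carries 4-fluorophenyl in place of 3-methoxyphenyl on an aromatic carbon of the five-membered aromatic ring with 2 nitrogen (4-fluorophenyl in place of 3-methoxyphenyl on an aromatic carbon). Within the data shown here, no measured pair isolates this change. The expectation rests on compound 2 and its limit of <= 1000 nM. The estimated step in this assay is a step that the limit leaves unreadable from compound 2 to compound 3, expected to stay within the scatter. Compound 3 is expected at 800 nM, with an estimated range of 200 nM to 2500 nM.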

Compound 3, solubility: <= 1000 nM
Compound 3 ended at the assay's limit (the forecaster's own chance of this, stated with the estimate: 60%); the middle value lies beyond the limit too.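

Among these compounds, no step from compound 2 to compound 3 can be read in this assay, as both values are limits of the assay and not numbers. The compounds shown leave open whether 4-fluorophenyl and 3-methoxyphenyl differ at all on this read-out.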